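The source may report more compounds than this note shows. Statements on the series, on what has been measured and on what is new or still open speak of the compounds shown alone.

In an ADME assay on J774.1 cells (Mus musculus) for cytotoxicity, read by resazurin assay, with a stated time of 48 h (on this read-out higher numbers stand for weaker inhibition and lower numbers for stronger inhibition), compound 3 (`CCCCn1cc(C(=O)NCc2ccc(OC)cc2)c(=O)c2cc(F)c(N3CCC(C(N)=O)CC3)cc21`) gives 40800 nM while compound 1 (`NC(=O)C1CCN(c2cc3c(cc2F)c(=O)c(C(=O)NCc2ccccc2)cn3C2CC2)CC1`) gives 51200 nM and the two lie within the usual scatter of each other. Compound 2 (`NC(=O)C1CCN(c2cc3c(cc2F)c(=O)c(C(=O)O)cn3C2CC2)CC1`) shows > 100000 nM as a limit of the assay and not a number. Within the data shown here, the one measured step (an at least 1.9-fold higher number from compound 1 to compound 2 (0.29 log units; that floor lies within the scatter)) puts hydroxy in place of benzylamino on a carbonyl carbon and ends at that limit (the limit of > 100000 nM in this assay, at which 1 of the 3 values shown sits). Compound 4 (`COc1ccc(CNC(=O)c2cn(C3CC3)c3cc(N4CCC(C(N)=O)CC4)c(F)cc3c2=O)cc1`) differs from compound 3 by cyclopropyl in place of butyl on an aromatic nitrogen with cyclopropyl in place of butyl on an aromatic nitrogen. Among the measured compounds shown here, no measured step covers that change. Compound 1 also carries cyclopropyl there and gives 51200 nM in this assay so no step beyond the scatter is expected. The estimated step (a 1.1-fold higher number from compound 3 to compound 4 (0.04 log units; within the scatter)) is therefore small. Compound 4 is estimated at 45000 nM with an expected range from 22000 nM to 90000 nM in this read-out.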

Compound 4, half-maximal inhibitory concentration: > 100000 nM
Compound 4 was reported as a limit (the forecaster's own chance of this, stated with the estimate: 8%); middle value at least 2.2-fold (0.34 log units) away from the limit.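

Among these compounds, on the aromatic nitrogen, cyclopropyl in place of butyl gives an at least 2.4-fold higher number from compound 3 to compound 4 (0.38 log units; beyond the scatter) in this assay, so a change at this position can move the number beyond the scatter, which no earlier step showed. Methoxy in place of hydrogen on an aromatic carbon gives an at least 1.9-fold higher number from compound 1 to compound 4 (0.29 log units; that floor lies within the scatter). Compound 4 is reported as a limit and not a number, as is compound 2, and the step between these two cannot be read: the limit of > 100000 nM in this assay, at which 2 of the 4 values shown sit.

On these data alone, how an ethyl group or a longer chain such as hexyl on that nitrogen would read remains open. As far as these compounds go, the full size of the step to compound 4 also remains open.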